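The source may hold more compounds than are shown below. What is called first, only, known or untested is meant among the compounds shown, and "the series" means these compounds.

Among the measured compounds shown here, compound 3 `Cc1ccc(OCC(=O)N(C)Cc2cccs2)cc1` is one of three compounds measured in an assay on HEK293 cells for agonist activity at transient receptor potential cation channel subfamily M member 8 (Homo sapiens), read by fluorescence and calcium flux, with a stated time of 15 min; a lower number here means that less compound is needed, a higher number that more compound is needed for the effect. Compound 1 `Cc1ccc(OCC(=O)N(Cc2cccs2)c2nccs2)cc1` gives 2240 nM in this assay, compound 2 `CCN(Cc1cccs1)C(=O)COc1ccc2c(c1)CCC2` gives 0.8 nM, and compound 3 gives 400 nM. On these numbers compound 3 stands second highest: its nearest neighbour is compound 1, whose number is higher, while compound 2 lies far below both. For the measured compounds named here, the only single-point step among the measured compounds is a 5.6-fold lower number from compound 1 to compound 3 (0.75 log units; beyond the scatter), a modest step that concerns the group on the amide-type nitrogen. Compound 2 differs from compound 3 in more than one place, so its value alone tells nothing about any single change.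

Compound 4 `Cc1ccc(OCC(=O)N(CCCO)Cc2cccs2)cc1` differs from compound 3 by 2-hydroxyethyl in place of hydrogen on a saturated chain carbon bound to an amide-type nitrogen. Going by the values given here, no measured step bears directly on this change; the step from compound 1 to compound 3 touches the neighbouring nitrogen, not the saturated chain carbon itself, and it was only modest. With no guidance in either direction, the expected step in this assay, a 1.5-fold higher number from compound 3 to compound 4 (0.18 log units; within the scatter), is small and uncertain. Compound 4 is therefore expected to give about 600 nM in this assay, within a range from 150 nM to 2500 nM.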

Compound 4, half-maximal effective concentration: 3000 nM
Compound 4: middle estimate off by 5.0-fold (0.70 log units), on the low side, outside the stated range (above it).
By their numbers in this assay, from the lowest: compound 2; then compound 3; then compounds 1 and 4 (each within the scatter of the next).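

At the saturated chain carbon bound to an amide-type nitrogen, the first change shown in this assay is not neutral: the step is a 7.5-fold higher number from compound 3 to compound 4 (0.88 log units; beyond the scatter) and it comes from adding 2-hydroxyethyl, which reads as methyl becoming 3-hydroxypropyl. Among the three compounds that share this core, methyl on the nitrogen now gives the lowest number, while the step of a 1.3-fold higher number from compound 1 to compound 4 (0.13 log units; within the scatter) shows that 3-hydroxypropyl and 1,3-thiazol-2-yl cannot be told apart in this assay, although the two groups have quite different names and make-up. Nothing available accounts for this rise in the number.

The compounds shown leave open whether the rise goes with the added chain or with its terminal hydroxyl, a question that a plain propyl, a methoxypropyl ether, a primary amine or a carboxylic acid at the same place would address. They also leave open whether the same change would have a step of similar size on the core of compound 2, whose number lies far below the others.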